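Propargylsulfanyl to methylsulfanyl on the chloro-alkyne side chain

This account rests on a few compounds, and the source may have more. Where it says the series, first, only, none or still open, it means among the compounds named here.

Measured so far:
compound 1 `CSc1cnc2ccccc2c1SCC#CCOC(=O)/C=C/c1ccccc1` — 18.1 ug/mL
compound 2 `C#CCSc1cnc2ccccc2c1SCC#CCOC(=O)/C=C/c1ccccc1` — 50.9 ug/mL
compound 3 `C#CCSc1cnc2ccccc2c1SCC#CCCl` — 2.9 ug/mL

In a functional assay on CCRF-CEM cells (Homo sapiens) for antiproliferative activity, with a stated time of 72 h (on this read-out lower numbers stand for stronger inhibition and higher numbers for weaker inhibition), compound 3 stands at the lowest number of the three, and its gaps to compound 1 and compound 2 both lie beyond the scatter. Between compound 2 and compound 1 the single change hydrogen in place of ethynyl on a saturated chain carbon bound to a sulfur gave a 2.8-fold lower number from compound 2 to compound 1 (0.45 log units; beyond the scatter).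

Compound 4 `CSc1cnc2ccccc2c1SCC#CCCl` carries the same change relative to compound 3: hydrogen in place of ethynyl on a saturated chain carbon bound to a sulfur. The difference between the core of compound 3 and that of compound 2 is not broken down here. For compound 4 a step of similar size and direction is expected, a 2.2-fold lower number from compound 3 to compound 4 (0.35 log units; beyond the scatter), resting on the step of a 2.8-fold lower number from compound 2 to compound 1 (0.45 log units; beyond the scatter) seen in the other pair. The estimate for compound 4 in this assay is 1.3 ug/mL, with a range from 0.5 ug/mL to 4 ug/mL.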

Compound 4, concentration for 50% inhibition: 2.5 ug/mL
Compound 4: the middle estimate sits 1.9-fold (0.28 log units) below what was measured, and the stated range covers the measured number.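

In this assay, replacing propargylsulfanyl with methylsulfanyl on the chloro-alkyne side chain gives a 1.2-fold lower number from compound 3 to compound 4 (0.06 log units; within the scatter), so on this core the change produces no step beyond the scatter. Set beside the earlier pair, the two steps cannot be told apart: the same change on two cores in this assay, a 2.8-fold lower number (0.45 log units; beyond the scatter) from compound 2 to compound 1 and a 1.2-fold lower number (0.06 log units; within the scatter) from compound 3 to compound 4, 2.4-fold (0.38 log units) apart, within the scatter of two such steps. The change therefore carries between these two cores without a detectable dependence on the core, but two pairs cannot settle whether its true size is nearer the smaller or the larger step, and they say nothing about other cores.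

Left open is how a longer chain in place of the methyl on the sulfur would read. On these data alone, an amine in place of the chlorine on the side chain also remains open.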